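Removing an acetyl from a diacylated disaccharide octyl glycoside

The compounds below may be only part of what the source reports. "The series", "measured", "known", "first", "only" and "open" are said of these compounds alone.

Measured compounds:
- compound 1 `CCCCCCCCO[C@@H]1O[C@@H](C)[C@H](OC(=O)CCCCC)[C@@H](O[C@@H]2O[C@@H](C)[C@H](OC(C)=O)[C@@H](O)[C@H]2OC(C)=O)[C@H]1O`; in a functional assay on NCI-H460 cells (Homo sapiens) for antiproliferative activity, read by MTT assay, with a stated time of 48 h (on this read-out higher numbers stand for weaker inhibition and lower numbers for stronger inhibition), compound 1 gives > 500000 nM, which is a limit of the assay and not a number.
- compound 2 `CCCCCCCCO[C@@H]1O[C@@H](C)[C@H](OC(=O)CCCCC)[C@@H](O[C@@H]2O[C@@H](C)[C@H](OC(C)=O)[C@@H](OC(C)=O)[C@H]2OC(C)=O)[C@H]1O`; in this assay compound 2 gives 15000 nM.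

Compound 2 stands with the only number shown in this assay; the other value shown is a limit. For the measured compounds named here, one measured step bears on the change now considered: an at least 33-fold lower number from compound 1 to compound 2 (1.52 log units; beyond the scatter), a large step, with compound 1 sitting at the limit of > 500000 nM in this assay, at which 1 of the 2 values shown sits.

Compound 3 `CCCCCCCCO[C@@H]1O[C@@H](C)[C@H](OC(=O)CCCCC)[C@@H](O[C@@H]2O[C@@H](C)[C@H](O)[C@@H](OC(C)=O)[C@H]2OC(C)=O)[C@H]1O` differs from compound 2 by hydrogen in place of acetyl on an oxygen on a saturated carbon. This is the reverse of the kind of change measured between compound 1 and compound 2, carried out at a different oxygen on a saturated carbon. Since adding an acetyl lowered the number by a large amount, taking one away is expected to raise it, and the step of a 10-fold higher number from compound 2 to compound 3 (1.00 log units; beyond the scatter) is expected to be large, toward weaker inhibition in this assay. Compound 3 is therefore estimated at 150000 nM, with a range from 30000 nM to 500000 nM, and a real chance that only a limit is reported.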

Compound 3, half-maximal inhibitory concentration: 151000 nM
Beside the measured number, compound 3's estimate is 1.0-fold (0.00 log units) below it, within the range that was stated.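

The change acetoxy to hydroxy at this oxygen on a saturated carbon gives a 10-fold higher number from compound 2 to compound 3 (1.00 log units; beyond the scatter) in this assay, so the acetyl here carries part of the activity of compound 2. This step has a number at both ends and its size can be read directly, whereas the earlier step, an at least 33-fold lower number from compound 1 to compound 2 (1.52 log units; beyond the scatter), starts from a limit and gives only a bound on its size. Taken together, the two steps show that losing an acetyl from either of two different oxygens of compound 2 moves the read-out toward weaker inhibition, and no compound shown goes against this within the series.

From the compounds shown here alone, compound 1 remains a limit, so the size of the loss at its oxygen cannot be set against the size measured here: the limit of > 500000 nM in this assay, at which 1 of the 3 values shown sits. Still open are the effect of removing the third acetyl alone, and whether a benzoyl ester or an amine at this oxygen would keep the activity of compound 2 or fall back toward that of compound 3.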